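The compounds below may be only part of what the source reports. "The series", "measured", "known", "first", "only" and "open" are said of these compounds alone.

Working notes on the series, measured in an assay on HEK293 cells for displacement of a labelled ligand from 5-hydroxytryptamine receptor 6 (Homo sapiens); a higher number here means a weaker inhibitor, a lower number a stronger inhibitor:

- compound 1 `O=C1c2ccccc2S(=O)(=O)N1CCCCN1CCN(c2cccc(Cl)c2Cl)CC1` gives 2660 nM
- compound 2 `O=C1c2ccccc2S(=O)(=O)N1CCCCCN1CCN(c2cccc(Cl)c2Cl)CC1` gives 197 nM
- compound 3 `COc1ccccc1N1CCN(CCCCCN2C(=O)c3ccccc3S2(=O)=O)CC1` gives 1990 nM

Compound 3 sits second highest of the three numbers; its value is within the scatter of compound 1, while compound 2 stands apart, as the step of a 10-fold higher number from compound 2 to compound 3 (1.00 log units; beyond the scatter) shows.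

Compound 4 `O=C1c2ccccc2S(=O)(=O)N1CCCCCN1CCN(c2ccccc2)CC1` is the next member. Its difference from compound 3: hydrogen in place of methoxy on an aromatic carbon. The replaced group sits on an aromatic carbon of a six-membered aromatic ring of carbon only, ortho to a large group.

Within the data shown here, only one measured step touches this aryl group, a 10-fold higher number from compound 2 to compound 3 (1.00 log units; beyond the scatter), and it swaps a 2,3-dichlorophenyl for a 2-methoxyphenyl rather than removing the methoxy. Among the measured compounds shown here, no measured pair shows methoxy against hydrogen on this ring, so the direction of the change is not directly supported. The expectation is therefore a small step, a 1.5-fold higher number from compound 3 to compound 4 (0.18 log units; within the scatter), leaning toward a somewhat higher number but possibly not beyond the scatter. Compound 4 is estimated at 3000 nM, in the range 1000 nM to 9000 nM.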

Compound 4, inhibition constant: 1840 nM
Compound 4: the middle estimate sits 1.6-fold (0.21 log units) above what was measured; low and high end bracket the measured number.
By their numbers in this assay, from the lowest: compound 2; then compounds 4, 3 and 1 (each within the scatter of the next).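

In this assay, hydrogen in place of methoxy on this aromatic carbon gives a 1.1-fold lower number from compound 3 to compound 4 (0.03 log units; within the scatter), so the methoxy group makes no readable difference here: 2-methoxyphenyl and phenyl cannot be told apart. The other new step, a 9.3-fold higher number from compound 2 to compound 4 (0.97 log units; beyond the scatter), lies beyond the scatter, as does a 10-fold higher number from compound 2 to compound 3 (1.00 log units; beyond the scatter), so compound 2 keeps the lowest number against both of these aryl groups, and among the three compounds with this chain only the 2,3-dichlorophenyl group goes with the lower number. No measurement on hand gives a reason for either step.

Which of the two chlorines goes with the lower number of compound 2 remains open, since no compound here carries a single chlorine on this ring. As far as these compounds go, whether a fluorine or a methyl group on the ring would behave like chlorine or like hydrogen also remains open.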